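The source may hold more compounds than are shown below. What is called first, only, known or untested is meant among the compounds shown, and "the series" means these compounds.

In a functional assay on SNB-19 cells (Homo sapiens) for inhibition, read by sulforhodamine B assay, with a stated time of 48 h, tested at 10 uM (a higher number here means more inhibition at the concentration tested (going by the name of the read-out), a lower number less inhibition), compound 2 `Fc1ccc(-c2cn3ccnc3c(-c3ccc4ncn(C5CCCCC5)c4c3)n2)cc1` gives 14.2%. Its only comparator, compound 1 `c1ccc(-c2cn3ccnc3c(-c3ccc4ncn(C5CCCCC5)c4c3)n2)cc1`, gives 22.9%, and the step of a number 8.7 percentage points lower from compound 1 to compound 2 (within the scatter) lies within the scatter, so the two stand level. Compound 3 `COc1ccccc1-c1cn2ccnc2c(-c2ccc3ncn(C4CCCCC4)c3c2)n1` differs from compound 2 by 2-methoxyphenyl in place of 4-fluorophenyl on an aromatic carbon. Going by the values given here, no measured step exchanges one substituted phenyl for another at this position; the single step from compound 1 to compound 2 bears on it only loosely, showing that a change on this ring has so far produced nothing beyond the scatter. Compound 3 is therefore expected to show a number 5.8 percentage points higher from compound 2 to compound 3 (within the scatter), with an estimate of 20% and a range from 5% to 40%.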

Compound 3, a percentage reported as inhibition, at one concentration (the size of the read-out at that concentration, not a potency): 11.1%
Estimate against measurement, compound 3: 8.9 percentage points above, and the stated range covers the measured number.
By their numbers in this assay, from the lowest: compounds 3, 2 and 1 (each within the scatter of the next, the first and the last beyond it).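

In this assay, 2-methoxyphenyl in place of 4-fluorophenyl gives a number 3.1 percentage points lower from compound 2 to compound 3 (within the scatter) and so leaves these two substituted phenyls level at this position. Methoxy in place of hydrogen on the same ring gives a number 11.8 percentage points lower from compound 1 to compound 3 (beyond the scatter) and is the first step on this ring beyond the scatter, though a modest one. No evidence bears on what lies behind this step.
Open, going by these compounds, is whether the number on this ring depends on the group itself: an amine or a carboxylic acid on the phenyl could stand level with compound 1 or fall further.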